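The source may hold more compounds than are shown below. What is called first, only, known or untested is meant among the compounds shown, and "the series" means these compounds.

Cytotoxicity notes on the shared core. In an ADME assay on MT4 cells (Homo sapiens) for cytotoxicity, read by MTT assay, with a stated time of 5 days (a lower number here means that less compound is tolerated, a higher number that more compound is tolerated), compound 1 `Cc1cc(C)c(Oc2cc(Nc3ccc(C#N)cc3)ncc2C(=O)NCc2cn(Cc3ccc(F)cc3)nn2)c(C)c1` reaches only a limit of the assay, >= 153000 nM. Compound 3 `Cc1cc(C)c(Oc2cc(Nc3ccc(C#N)cc3)ncc2C(=O)NCc2cn(Cc3ccccc3F)nn2)c(C)c1` likewise sits at a limit in this assay, > 222000 nM. Within the data shown here, compound 2 `COC(=O)Cn1cc(CNC(=O)c2cnc(Nc3ccc(C#N)cc3)cc2Oc2c(C)cc(C)cc2C)nn1` gives the single actual number in this assay, 13800 nM. Compound 2 is therefore the one fixed point on the scale. Compound 4 `Cc1cc(C)c(Oc2cc(Nc3ccc(C#N)cc3)ncc2C(=O)NCc2cn(CC(=O)N3CCCC3)nn2)c(C)c1` keeps the carbonyl of compound 2 on the saturated chain carbon bound to an aromatic nitrogen and differs only in what that carbonyl carries: pyrrolidin-1-yl in place of methoxy on a carbonyl carbon. The measured steps that touch this position are an at least 11-fold lower number from compound 1 to compound 2 (1.04 log units; beyond the scatter) and an at least 16-fold higher number from compound 2 to compound 3 (1.20 log units; beyond the scatter), both large, but both replace the whole methoxycarbonyl with a fluorophenyl, whereas compound 4 retains the carbonyl. Those steps therefore do not fix the size here; a moderate rise in this assay is expected, a 1.8-fold higher number from compound 2 to compound 4 (0.26 log units; within the scatter). Compound 4 is expected to give 25000 nM, within a range from 8000 nM to 80000 nM.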

Compound 4, half-maximal cytotoxic concentration: 58100 nM
Compound 4: middle estimate off by 2.3-fold (0.37 log units), on the low side, within the range that was stated.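

Among these compounds, with the carbonyl kept, what it carries still moves the number in this assay: a 4.2-fold higher number from compound 2 to compound 4 (0.62 log units; beyond the scatter), a change confined to the group on the carbonyl carbon, which the earlier steps, replacing the whole methoxycarbonyl, could not isolate. The (pyrrolidin-1-yl)carbonyl group does not reach the fluorophenyl compounds, with an at least 3.8-fold lower number from compound 3 to compound 4 (0.58 log units; beyond the scatter) and an at least 2.6-fold lower number from compound 1 to compound 4 (0.42 log units; beyond the scatter). Both of these steps start from limits of the assay and give only a minimum size, and compound 3 stands at one such limit: the limit of > 222000 nM in this assay, at which 1 of the 4 values shown sits.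

The compounds shown leave open whether the rise follows the pyrrolidine ring itself or simply the nitrogen on the carbonyl carbon. A dimethylamino group or an open-chain diethylamino group at that place would separate the two, and a carboxylic acid there would show how far the number falls on the other side of methoxy.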